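This account rests on a few compounds, and the source may have more. Where it says the series, first, only, none or still open, it means among the compounds named here.

Measured in a functional assay on 3T3-L1 cells (Mus musculus) for inhibition, with a stated time of 20 min, tested at 20 uM; a higher number here means more inhibition at the concentration tested (going by the name of the read-out), a lower number less inhibition:

Compound 1, `Cc1ccc(S(=O)(=O)N(Cc2cn(Cc3ccc(F)cc3F)nn2)Cc2cn(S(=O)(=O)c3ccc(C)cc3)c3ccccc23)cc1`: 12.3%
Compound 2, `Cc1ccc(S(=O)(=O)n2c(CN(Cc3cn(Cc4ccc(F)cc4F)nn3)S(C)(=O)=O)c(C)c3ccccc32)cc1`: -20.8%
Compound 3, `Cc1ccc(S(=O)(=O)N(Cc2cn(Cc3cc(F)ccc3F)nn2)Cc2cn(S(=O)(=O)c3ccccc3)c3ccccc23)cc1`: -6.5%

Compound 1 stands highest of these three numbers. Its nearest neighbour is compound 3, whose number lies lower by a gap beyond the usual scatter, and furthest from it is compound 2, whose number lies lower by a gap also beyond the scatter. None of the three pairs differs in only one place, so no single-change step can be read from them.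

The next compound, compound 4, `COc1ccc(Cn2cc(CN(Cc3cn(S(=O)(=O)c4ccc(C)cc4)c4ccccc34)S(=O)(=O)c3ccc(C)cc3)nn2)cc1`, differs from compound 1 in one place: 4-methoxyphenyl in place of 2,4-difluorophenyl on a saturated chain carbon bound to an aromatic nitrogen. Within the data shown here, with no measured pair showing the effect of such a change, the expectation rests only on the spread of the numbers seen so far, which are all small. A step of modest size is expected in this assay, in no clear direction, and likely not beyond the scatter. Compound 4 is expected to give 6%, in a range from -14% to 26%. The estimate means an expected step of a number 6.3 percentage points lower from compound 1 to compound 4 (within the scatter).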

Compound 4, a percentage reported as inhibition, at one concentration (the size of the read-out at that concentration, not a potency): 1%
Compound 4: the middle estimate sits 5 percentage points above what was measured; the measured number falls inside the stated range.
By their numbers in this assay, from the lowest: compound 2; then compounds 3 and 4 (each within the scatter of the next); then compound 1.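

In this assay, exchanging 2,4-difluorophenyl for 4-methoxyphenyl on a saturated chain carbon bound to an aromatic nitrogen gives a number 11.3 percentage points lower from compound 1 to compound 4 (beyond the scatter), the only single-change step among these compounds. It shows that the number responds to what this position carries, though the step is modest and rests on one pair tested at one concentration, so it says nothing about potency. Nothing measured on these compounds accounts for the step.

This single exchange removes the two fluorines and adds the methoxy group together, so it cannot tell which part matters; a plain benzyl group or a 4-fluorobenzyl group here could separate them, and a carboxylic acid on the ring would test a very different kind of group. On these data alone, whether the same exchange would shift the number on the core of compound 2 also stays open.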